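Fluoro for Trifluoromethyl on the Aryl Piperazine of Compound 3

The compounds below may be only part of what the source reports. "The series", "measured", "known", "first", "only" and "open" are said of these compounds alone.

Measured compounds:
compound 1 `CCC(C(=O)N1CCN(c2ccccc2Cl)CC1)N1C(=O)CCC1=O`: 50%
compound 2 `CCC(C(=O)N1CCN(c2cccc(F)c2)CC1)N1C(=O)CCC1=O`: 75%
compound 3 `CCC(C(=O)N1CCN(c2ccc(C(F)(F)F)cc2)CC1)N1C(=O)CCC1=O`: 25%

In a functional assay on the whole organism (strain Swiss) with Mus musculus as the target, in the maximal electroshock model, with a stated time of 0.25 h, at a dose of 300 mg/kg by the intraperitoneal route (on this read-out higher numbers stand for a stronger effect at the one dose given and lower numbers for a weaker effect), compound 3 gives 25%, the lowest of the three numbers; compound 1 stands closest with 50% and compound 2 furthest with 75%. Compound 4 `CCC(C(=O)N1CCN(c2ccc(F)cc2)CC1)N1C(=O)CCC1=O` differs from compound 3 by fluoro in place of trifluoromethyl on an aromatic carbon. Among the compounds with values here, no measured step swaps these two groups. Within the data shown here, the one step on the aryl ring, a number 25 percentage points higher from compound 1 to compound 2 (beyond the scatter), shows that a change of substituent there can move the read-out beyond the scatter, and compound 2 carries a fluoro group with the highest number seen. A modest rise is therefore expected, a number 25 percentage points higher from compound 3 to compound 4 (beyond the scatter). Compound 4 is estimated at 50%, within 25% to 75%.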

Compound 4, a percentage reported as activity, at one dose (the size of the read-out at that dose, not a potency): 0%
For compound 4 the middle estimate is 50 percentage points above the measured one, and the stated range ends above it.
By their numbers in this assay, from the lowest: compound 4; then compound 3; then compound 1; then compound 2.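

In this assay, a fluoro group on the aryl ring does not by itself go with a high number: 4-fluorophenyl in place of 3-fluorophenyl gives a large fall (a number 75 percentage points lower from compound 2 to compound 4 (beyond the scatter)), so the two fluorophenyl isomers are clearly separated. Fluoro in place of trifluoromethyl also lowers the number (a number 25 percentage points lower from compound 3 to compound 4 (beyond the scatter)), and 4-fluorophenyl falls well short of 2-chlorophenyl (a number 50 percentage points lower from compound 1 to compound 4 (beyond the scatter)). Nothing measured here accounts for these steps. From the compounds shown here alone, what a methoxy group or an amine on this aromatic carbon would give remains open.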